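Replacing the chloro group in a weakly active urea series

This account rests on a few compounds, and the source may have more. Where it says the series, first, only, none or still open, it means among the compounds named here.

Measured so far:
compound 1 `Nc1nn(C(=O)Nc2ccc(Cc3ccccc3)cc2)c2ccccc12` — 43900 nM
compound 2 `Nc1nn(C(=O)Nc2ccc(Cc3ccccc3)cc2)c2ccc(Cl)cc12` — 37600 nM

In a functional assay on MDA-MB-231 cells (Homo sapiens) for antiproliferative activity, read by sulforhodamine B assay, with a stated time of 48 h (on this read-out higher numbers stand for weaker inhibition of growth and lower numbers for stronger inhibition of growth), compound 1 gives 43900 nM and compound 2 gives 37600 nM. Among the measured compounds shown here, the one measured step, a 1.2-fold lower number from compound 1 to compound 2 (0.07 log units; within the scatter), puts a chloro group in place of a hydrogen on an aromatic carbon and leaves the read-out essentially where it was. Compound 2 therefore carries the lower of the two numbers, but the gap to compound 1 is within the scatter, so no order between them can be claimed.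

Compound 3 `Nc1ccc2c(c1)c(N)nn2C(=O)Nc1ccc(Cc2ccccc2)cc1` differs from compound 2 in one place: amino in place of chloro on an aromatic carbon. For the measured compounds named here, no measured step exchanges a chloro group for an amino group, so the only step that bears on this change is the one from compound 1 to compound 2, which was itself within the scatter. On that basis the expectation for compound 3 in this assay is a step of a 1.1-fold higher number from compound 2 to compound 3 (0.03 log units; within the scatter), that is, no change beyond the scatter. Compound 3 is accordingly estimated at 40000 nM, with a range from 15000 nM to 100000 nM.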

Compound 3, concentration for total growth inhibition: 22700 nM
Compound 3: the middle estimate sits 1.8-fold (0.25 log units) above what was measured; measured number inside the range.
By their numbers in this assay, from the lowest: compounds 3, 2 and 1 (each within the scatter of the next).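

In this assay, the aromatic carbon of the six-membered ring, meta to a fused ring and para to a fused ring, now carries amino, which counts one hydrogen-bond donor and one hydrogen-bond acceptor where chloro counts neither, and this exchange gives a 1.7-fold lower number from compound 2 to compound 3 (0.22 log units; within the scatter). Read against hydrogen at the same place, amino gives a 1.9-fold lower number from compound 1 to compound 3 (0.29 log units; within the scatter), so hydrogen, chloro and amino have now all been compared here, and no step among the three compounds lies beyond the scatter; this position has so far tolerated a one-atom exchange that alters the donor and acceptor count without a change that can be claimed. No measurement is available to explain these numbers.

The compounds shown leave open whether a larger group at this position, such as an acetamide, a methoxy group or a carboxylic acid, would move the read-out beyond the scatter. They also leave open whether amino would give a step of any greater size at another aromatic carbon of the shared core.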